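Replacing chloro with carbamoyloxy on the shared core

The source may report more compounds than this note shows. Statements on the series, on what has been measured and on what is new or still open speak of the compounds shown alone.

Among the measured compounds shown here, in a functional assay on V79-379A cells (Cricetulus griseus) for cytotoxicity, read by MTT assay, in the presence of a further agent that is not named here (on this read-out higher numbers stand for weaker inhibition and lower numbers for stronger inhibition), compound 1 `COC1=CC(=O)c2c(c(CCl)cn2C)C1=O` gives 304000 nM, the highest of the three numbers measured so far. Compound 2 `COC1=CC(=O)c2c(c(COC(C)=O)c(C)n2C)C1=O` gives 27000 nM, and compound 3 `CCOC(=S)Sc1c2c(n(C)c1C)C(=O)C=C(OC)C2=O` gives 67000 nM. Both of these numbers lie clearly lower than that of compound 1.

Compound 4 `COC1=CC(=O)c2c(c(COC(N)=O)cn2C)C1=O` has not yet been measured. It carries carbamoyloxy in place of chloro on a saturated chain carbon bound to an aromatic carbon, so chloromethyl becomes (carbamoyloxy)methyl.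

For the measured compounds named here, no measured pair isolates this change. Going by the values given here, the one single-place step available, a 2.5-fold higher number from compound 2 to compound 3 (0.39 log units; beyond the scatter), is a modest one and concerns a different group on an aromatic carbon, so it shows only that a single swap on this core can move the number beyond the scatter. The nearest guide is compound 2 at 27000 nM, which also has an oxygen-linked group on the chain carbon, although it differs from compound 1 in more than one place. A fall in the number is therefore expected, of moderate size and with wide uncertainty. The expected change is a 5.1-fold lower number from compound 1 to compound 4 (0.70 log units; beyond the scatter). For compound 4 the estimated value in this assay is 60000 nM, with an expected range of 15000 nM to 240000 nM.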

Compound 4, half-maximal inhibitory concentration: 3000 nM
Compound 4: the middle estimate sits 20-fold (1.30 log units) above what was measured; the whole stated range lies above it.
By their numbers in this assay, from the lowest: compound 4; then compound 2; then compound 3; then compound 1.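

In this assay, among the compounds shown here, the saturated chain carbon bound to an aromatic carbon proves to be a place where one exchange can shift the number a long way: carbamoyloxy in place of chloro gives a 100-fold lower number from compound 1 to compound 4 (2.01 log units; beyond the scatter) and so supplies the first measured pair that isolates a change at this position. For the compounds shown here, this large step far exceeds a 2.5-fold higher number from compound 2 to compound 3 (0.39 log units; beyond the scatter) from the only earlier single-place comparison, which concerned a group on an aromatic carbon, and it puts compound 4 at 3000 nM as the lowest of the four numbers so far. Going by these compounds alone, nothing available bears on why this exchange moves the number so far.

What remains open is which part of the carbamoyloxy group matters, since the compounds shown give no reading for a hydroxyl, a methoxy or an amine on the same chain carbon, each of which would help separate the oxygen link from the rest of the group. They also leave open whether the same exchange would give a step of this size on a core that carries an additional methyl, as compound 2 does.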